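A few compounds are considered here, and "the series" means these few. Any claim that something is new, unique, unknown or untested is made for them only; others in the source may bear on it.

Measured compounds in a functional assay on BV-2 cells (Mus musculus) for inhibition, read by ELISA, with a stated time of 16 h; a higher number here means a weaker inhibitor, a lower number a stronger inhibitor:
- compound 1 `Cc1cc(-c2ccsc2)nnc1N1CCN(c2ncccn2)CC1`: 2400 nM
- compound 2 `Cc1cc(-c2cccnc2)nnc1N1CCN(c2ncccn2)CC1`: > 100000 nM

Compound 1 gives a clear number, 2400 nM. Compound 2 reaches only the limit of the assay, > 100000 nM, so for it a bound is known and not a number. Going by the values given here, the single measured step, an at least 41-fold higher number from compound 1 to compound 2 (1.61 log units; beyond the scatter), is large and well beyond the scatter, and compound 2 stands at the limit itself (the limit of > 100000 nM in this assay, at which 1 of the 2 values shown sits).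

Compound 3 `Cc1cc(-c2ccncc2)nnc1N1CCN(c2ncccn2)CC1` has not yet been measured. It differs from compound 2 by pyridin-4-yl in place of pyridin-3-yl on an aromatic carbon. Among the compounds with values here, no measured step moves the nitrogen within a pyridinyl ring, so the one measured step bears only indirectly: it shows that a pyridinyl group in place of thiophen-3-yl at this position brings a large loss, without telling whether the second pyridinyl matters. Compound 3 is therefore expected to stay near compound 2, with the expected step of a number no higher from compound 2 to compound 3 (the limit leaves the size open) being none beyond the scatter. Compound 3 is estimated at 100000 nM, with a likely range from 20000 nM to 500000 nM, and most likely the assay again reports only a limit.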

Compound 3, half-maximal inhibitory concentration: > 100000 nM
Compound 3: a limit, no number; the forecaster's own chance of this, stated with the estimate: 65%; the middle value sits exactly at the limit.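

The loss on leaving thiophen-3-yl does not depend on where the ring nitrogen sits in the new group: with pyridin-4-yl, as with pyridin-3-yl, this assay shows a large change, an at least 41-fold higher number from compound 1 to compound 3 (1.61 log units; beyond the scatter). In the same assay, compound 3 gives > 100000 nM, which is a limit of the assay and not a number. The step from compound 2 to compound 3 cannot be read, and any difference between these two pyridinyl groups stays hidden, because both compounds stand at the same limit: the limit of > 100000 nM in this assay, at which 2 of the 3 values shown sit.

Still open, from the compounds shown here alone, is whether a phenyl ring or a furan-3-yl group in place of thiophen-3-yl would stay close to compound 1, at 2400 nM, or would also bring a large loss. Also open, going by these compounds, is whether any ring carrying a nitrogen loses activity here, which pyridin-2-yl or a pyrimidinyl group in the same place would help to answer.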